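A few compounds are considered here, and "the series" means these few. Any claim that something is new, unique, unknown or untested is made for them only; others in the source may bear on it.

Of the compounds shown here, three have so far been measured in a functional assay for agonist activity at G protein-coupled receptor 88 (Homo sapiens), read by HTRF and cAMP accumulation; a lower number here means that less compound is needed, a higher number that more compound is needed for the effect. Compound 1 `CC(C)CCNCCN(C(=O)[C@@H]1C[C@H]1c1ccccc1)c1ccc(-c2ccccc2)cc1` gives 5.1 nM, compound 2 `CC[C@H](C)[C@H](N)CN(C(=O)[C@@H]1C[C@H]1c1ccoc1)c1ccc(-c2ccccc2)cc1` gives 580 nM, and compound 3 `CC(C)C[C@H](N)CN(C(=O)[C@@H]1C[C@H]1c1ccccc1)c1ccc(-c2cccs2)cc1` gives 1500 nM. Compound 3 thus has the highest of the three numbers, so the most material is needed for its effect; compound 2 comes nearest with a lower number, and compound 1 lies furthest away with a far lower number, both gaps beyond the usual scatter. Compound 4 `CC(C)C[C@H](N)CN(C(=O)[C@@H]1C[C@H]1c1ccccc1)c1ccc(-c2ccc(Cl)cc2)cc1` is not yet measured. It differs from compound 3 by 4-chlorophenyl in place of thiophen-2-yl on an aromatic carbon. Compound 1, with 5.1 nM, carries a six-membered aromatic ring of carbon only where compound 3 carries thiophen-2-yl, although its side chain also differs, so only a moderate gain is expected. A downward step is expected, a 3.3-fold lower number from compound 3 to compound 4 (0.52 log units; beyond the scatter). Compound 4 is estimated at 450 nM, within 120 nM to 1600 nM.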

Compound 4, half-maximal effective concentration: 640 nM
Compound 4: the middle estimate sits 1.4-fold (0.15 log units) below what was measured, and the stated range covers the measured number.
By their numbers in this assay, from the lowest: compound 1; then compounds 2 and 4 (each within the scatter of the next); then compound 3.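

For the compounds shown here, replacing thiophen-2-yl with 4-chlorophenyl on this aromatic carbon gives a 2.3-fold lower number from compound 3 to compound 4 (0.37 log units; beyond the scatter) and provides the only comparison so far in which just one place changes. The step is modest, but it shows that this position responds to the group it carries and that a six-membered aromatic ring of carbon only can stand there. No measurement at hand explains the change. Whether the chlorine or the ring itself accounts for the step stays open. Plain phenyl on this side chain would separate the two, while a methoxy group or a nitrile in place of the chlorine would test that spot further.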